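The source may report more compounds than this note shows. Statements on the series, on what has been measured and on what is new or still open speak of the compounds shown alone.

The measured compounds and their values:
compound 1, `COc1ccc2[nH]c3c(c2c1)CCNC31CCN(Cc2ccc(F)cc2F)CC1`: 2000 nM
compound 2, `Fc1ccc(CN2CCC3(CC2)NCCc2c3[nH]c3ccccc23)c(F)c1`: 8200 nM
compound 3, `Fc1ccc(CN2CCC3(CC2)NCCc2c3[nH]c3ccc(Br)cc23)c(F)c1`: 21000 nM

All three were tested in an assay on FRT cells for positive allosteric modulation of Cystic fibrosis transmembrane conductance regulator variant N1303K (Homo sapiens), in the presence of a further agent that is not named here; on this read-out higher numbers stand for an effect only at larger amounts of compound and lower numbers for an effect already at smaller amounts. Compound 2 holds the second highest of the three numbers: one step leads to compound 3 and is a 2.6-fold higher number from compound 2 to compound 3 (0.41 log units; beyond the scatter), the other leads back to compound 1 and, read from that side, is a 4.1-fold higher number from compound 1 to compound 2 (0.61 log units; beyond the scatter). Both steps lie beyond the scatter.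

Compound 4, `COc1ccc2c3c([nH]c2c1)C1(CCN(Cc2ccc(F)cc2F)CC1)NCC3`, has not yet been measured. It differs from compound 2 by methoxy in place of hydrogen on an aromatic carbon, on an aromatic carbon of a six-membered aromatic ring of carbon only, part of a fused system of four rings, meta to a fused ring and para to a fused ring. The step that bears on this is a 4.1-fold higher number from compound 1 to compound 2 (0.61 log units; beyond the scatter), in which removing a methoxy group raised the number. Here a methoxy group enters the same ring, but at a different position, so that step need not carry over in full. A lower number than that of compound 2 is therefore expected in this assay, of modest size. Compound 4 is estimated at 3500 nM, with a range from 1200 nM to 10000 nM, which corresponds to an expected step of a 2.3-fold lower number from compound 2 to compound 4 (0.37 log units; beyond the scatter).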

Compound 4, half-maximal effective concentration: 2400 nM
For compound 4 the middle estimate is 1.5-fold (0.16 log units) above the measured one; the measured number falls inside the stated range.
By their numbers in this assay, from the lowest: compounds 1 and 4 (each within the scatter of the next); then compound 2; then compound 3.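

In this assay, methoxy in place of hydrogen at this position, meta to a fused ring and para to a fused ring, gives a 3.4-fold lower number from compound 2 to compound 4 (0.53 log units; beyond the scatter) and lies beyond the scatter. The lower number therefore does not belong to a single place on this six-membered ring: compound 1 at 2000 nM and compound 4 at 2400 nM lie within the scatter of each other, so these values do not separate the two placements of methoxy. Nothing measured here explains why methoxy has this effect.

The compounds shown leave open whether the lower number belongs to methoxy itself or would also come with a hydroxyl, ethoxy or amino group at this position. They also leave open how bromo, which gave a 2.6-fold higher number from compound 2 to compound 3 (0.41 log units; beyond the scatter) at the other position, would behave at this one.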